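Methylsulfanyl to methylsulfinyl on the aryl of compound 3

The source may report more compounds than this note shows. Statements on the series, on what has been measured and on what is new or still open speak of the compounds shown alone.

Measured so far:
compound 1, `CC(C)OC(=O)N1CCC(Oc2ncnc3c2CCN3c2ccc(C#N)cc2F)CC1`: 134%
compound 2, `CC(C)OC(=O)N1CCC(Oc2ncnc3c2CCN3c2ccc(C#N)cn2)CC1`: 105%
compound 3, `CSc1ccc(N2CCc3c(OC4CCN(C(=O)OC(C)C)CC4)ncnc32)cc1F`: 121%

All three were measured in a functional assay on CHO-K1 cells with Glucose-dependent insulinotropic receptor (Homo sapiens) as the target, read by a luciferase reporter, with a stated time of 5 h; a lower number here means a smaller maximal response, a higher number a larger maximal response. Compound 3 stands second of the three: a number 13 percentage points lower from compound 1 to compound 3 (beyond the scatter) places it under compound 1, and a number 16 percentage points higher from compound 2 to compound 3 (beyond the scatter) places it over compound 2. The remaining step, a number 29 percentage points lower from compound 1 to compound 2 (beyond the scatter), is the largest of the set. Each of these steps exchanges the whole group on the nitrogen on the aromatic ring in the ring; none alters a single substituent on that aryl group while keeping the rest in place.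

Compound 4, `CC(C)OC(=O)N1CCC(Oc2ncnc3c2CCN3c2ccc([S@@+](C)[O-])c(F)c2)CC1`, keeps everything of compound 3 except one change: a group of 3 heavy atoms (1 carbon, 1 oxygen, 1 sulfur; no ring) in place of a group of 2 heavy atoms (1 carbon, 1 sulfur; no ring), on an aromatic carbon. The methylsulfanyl group leaves and the group of one carbon, one oxygen and one sulfur enters, on an aromatic carbon of a six-membered aromatic ring of carbon only, ortho to a fluoro group and para to a large group. Within the data shown here, no measured pair tests a change of this kind, so the measured steps give only the span of the series and no direction for it. A step within the scatter, or at most a modest fall, is expected: a number 3 percentage points lower from compound 3 to compound 4 (within the scatter). Compound 4 is therefore estimated at 118%, with a range from 100% to 136%.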

Compound 4, largest response reached (reported as percent of maximum), in percent of the reference or control that the assay uses: 155%
Estimate against measurement, compound 4: 37 percentage points below, outside the stated range (above it).
By their numbers in this assay, from the lowest: compound 2; then compound 3; then compound 1; then compound 4.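

In this assay, among these compounds, the change from methylsulfanyl to methylsulfinyl gives the first reading of a single substituent on the aryl group while the rest stays in place: a number 34 percentage points higher from compound 3 to compound 4 (beyond the scatter) on an aromatic carbon, ortho to a fluoro group and para to a large group. This shows that the position is not silent for maximal response, even though the counts of hydrogen-bond donors and acceptors stay the same and the entering group adds one defined stereocentre. The whole-group exchanges on the nitrogen also extend the span of the series, with a number 50 percentage points higher from compound 2 to compound 4 (beyond the scatter) and a number 21 percentage points higher from compound 1 to compound 4 (beyond the scatter) as readings, and nothing shown gives a reason for any of these steps.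

Open, from the compounds shown here alone, is whether the response follows the oxidation state of the sulfur, which methylsulfonyl at the same aromatic carbon, with a second oxygen on the sulfur, and the opposite configuration at the stereocentre would address. Also open, going by these compounds, is whether the position tolerates groups without sulfur, such as an amine, a carboxylic acid or a longer alkyl chain, and whether the fluoro group is needed for the step seen here.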